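Swapping Tert-Butyl for Propyl on a Urea Nitrogen

The source may hold more compounds than are shown below. What is called first, only, known or untested is meant among the compounds shown, and "the series" means these compounds.

Two compounds have been measured in an assay on isolated protein for inhibition of histamine H2 receptor (Cavia porcellus); a higher number here means weaker binding, a lower number tighter binding:
Compound 1, `COc1ccc(N/C(S)=N/CCCOc2cccc(CN3CCCCC3)c2)cc1`, gives 4370 nM.
Compound 2, `CC(C)(C)NC(=O)NCCCOc1cccc(CN2CCCCC2)c1`, gives 2090 nM.

Of these two numbers, compound 2 has the lower one, and compound 1 stands at a higher number, a gap that lies beyond the usual scatter of this assay. Among the compounds with values here, the two compounds differ from each other in more than one place, so no single-change step connects them; their two values simply stand side by side, and compound 2 is the one whose number is lower.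

Compound 3, `CCCNC(=O)NCCCOc1cccc(CN2CCCCC2)c1`, has not yet been measured. It differs from compound 2 in one place only: propyl in place of tert-butyl on an amide-type nitrogen. Both groups are small chains made of carbon alone, carrying no hydrogen-bond donors or acceptors and no charge, so nothing in the count of atoms suggests a large shift. Within the data shown here, with only one measured neighbour and no computed steps to lean on, the expectation for compound 3 is a change close to that of compound 2, of a size within or near the scatter, and compound 3 is expected to give 2500 nM, in a range from 900 nM to 7000 nM, which means an expected step of a 1.2-fold higher number from compound 2 to compound 3 (0.08 log units; within the scatter).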

Compound 3, dissociation constant: 97.7 nM
Beside the measured number, compound 3's estimate is 26-fold (1.41 log units) above it; the measured number lies below the stated range.
By their numbers in this assay, from the lowest: compound 3; then compound 2; then compound 1.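

In this assay, propyl in place of tert-butyl on an amide-type nitrogen gives a 21-fold lower number from compound 2 to compound 3 (1.33 log units; beyond the scatter), which shows that one small change at this single place can move binding strongly. Within the data shown here, compound 1 and compound 2 differ in more than one place, so their values could not tie any effect to one position; this step is the first to do so. The two groups match in having no ring, no hydrogen-bond donors or acceptors and no net charge, so those simple counts give no warning of a step this large, and no measurement at hand explains it.

Among these compounds, with only this one pair to compare at the position, it remains open whether the tighter binding reflects something particular to propyl or simply the departure of tert-butyl. Ethyl, isopropyl, butyl or a longer chain on the same nitrogen could show whether binding changes gradually with the group or only for certain chains, and an amine or a carboxylic acid at the chain's end could test whether carbon alone is needed there.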